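This account rests on a few compounds, and the source may have more. Where it says the series, first, only, none or still open, it means among the compounds named here.

Compound 1 `O=C1NCc2ncc(-c3ccc(-c4cncc(NS(=O)(=O)c5ccc(F)cc5F)c4)s3)cc21` gives 100%
Compound 2 `COc1ncc(-c2ccc(-c3cnc4c(c3)CN(C)C4=O)s2)cc1NS(=O)(=O)c1ccccc1[N+](=O)[O-]` gives 80%
Compound 3 `CN1Cc2cc(-c3ccc(-c4cncc(NS(=O)(=O)c5cccc(C(F)(F)F)c5)c4)s3)cnc2C1=O` gives 84%

These numbers come from an ADME assay on microsomes from liver (Rattus norvegicus, strain Sprague-Dawley) for metabolic stability, read by LC-MS, using NADPH, with a stated time of 30 min, tested at 3 uM; a lower number here means that less of the compound is left, a higher number that more of the compound is left. Compound 2 lies within the usual scatter of compound 3 and clearly under compound 1 , so a good share of it survives, though not all. Compound 4 `COc1ncc(-c2ccc(-c3cnc4c(c3)CN(C)C4=O)s2)cc1NS(=O)(=O)c1ccccc1C(F)(F)F` keeps the rest of compound 2 but has trifluoromethyl in place of nitro on an aromatic carbon, ortho to a large group: trifluoromethyl in place of nitro on an aromatic carbon. Going by the values given here, no measured pair shows this swap alone. Compound 3 also carries a trifluoromethyl group and gives 84%, which offers only indirect guidance. The expected change is a number 2 percentage points higher from compound 2 to compound 4 (within the scatter), with no step beyond the scatter anticipated. For compound 4 the estimated value is 82%, with an expected range from 66% to 97%.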

Compound 4, percent of the compound remaining in the Rattus norvegicus assay: 50%
Compound 4: the middle estimate sits 32 percentage points above what was measured, and the stated range ends above it.
By their numbers in the Rattus norvegicus assay, from the lowest: compound 4; then compounds 2 and 3 (each within the scatter of the next); then compound 1.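

Going by these compounds alone, in the Rattus norvegicus assay, trifluoromethyl in place of nitro gives a number 30 percentage points lower from compound 2 to compound 4 (beyond the scatter), the only single-place change in this set, with compound 2 at 80% and compound 4 at 50%, so what sits at this position matters for how much compound is left. In a physicochemical assay for solubility, read by HPLC (a higher number here means a more soluble compound, a lower number a less soluble compound), the same change gives a 1.5-fold higher number from compound 2 to compound 4 (0.18 log units; within the scatter), with compound 2 at 4810 ug/mL and compound 4 at 7340 ug/mL, so the two compounds cannot be told apart on solubility. Nothing available explains the loss in the microsomes.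

As far as these compounds go, whether a nitrile or an amine on this aromatic carbon would leave more compound stays open. So does whether the same swap would act alike on another compound.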